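Methoxy to trifluoromethyl at a solubility limit

The source may report more compounds than this note shows. Statements on the series, on what has been measured and on what is new or still open speak of the compounds shown alone.

Three compounds measured so far in a physicochemical assay for solubility, using the shake flask method, in phosphate buffer, measured as kinetic solubility, with a stated time of 20 h, at pH 6.5; on this read-out higher numbers stand for higher solubility and lower numbers for lower solubility

Compound 1 `COc1ccc(Nc2cc3[nH]c(-c4cccc(C(F)(F)F)c4)nc3cn2)nc1` gives < 5000 nM as a limit
Compound 2 `FC(F)(F)c1cccc(-c2nc3cnc(Nc4cnccn4)cc3[nH]2)c1` gives < 5000 nM as a limit
Compound 3 `Fc1ccc(-c2nc3cnc(Nc4ccccn4)cc3[nH]2)cc1F` gives < 5000 nM as a limit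

Compound 1 has only the limit < 5000 nM and no exact number. Within the data shown here, the whole set offers the same picture, with the limit of < 5000 nM in this assay, at which 3 of the 3 values shown sit, as its only evidence.

Compound 4 `FC(F)(F)c1ccc(Nc2cc3[nH]c(-c4cccc(C(F)(F)F)c4)nc3cn2)nc1` differs from compound 1 in one group, trifluoromethyl in place of methoxy on an aromatic carbon and the shared core stays as it is. The closest measured change replaces the same 5-methoxypyridin-2-yl group, yet a step that the two limits leave unreadable from compound 1 to compound 2 offers neither a size nor a direction to carry over. No step beyond the usual scatter can therefore be argued, and another limit is the likeliest report. The estimated step is a step that the limit leaves unreadable from compound 1 to compound 4 and it rests on very little. In this assay the expected value for compound 4 is 3000 nM with 1000 nM to 5000 nM as the estimated range.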

Compound 4, solubility: < 5000 nM
Compound 4: a limit, no number; the forecaster's own chance of this, stated with the estimate: 90%; the middle value is on the limit's open side.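

Compound 4 also gives only a limit in this assay, so no step can be read from compound 1 or compound 2 to compound 4. The exact values of all four compounds and their order remain open, with every result resting on the same limit: the limit of < 5000 nM in this assay, at which 4 of the 4 values shown sit.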